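A few compounds are considered here, and "the series" means these few. Any claim that something is new, unique, unknown or untested is made for them only; others in the source may bear on it.

Measured compounds and their results:

Compound 1 `COc1ccc(CNc2nc([SeH])nc3ccccc23)cc1` gives 7110 nM in a functional assay on HTB-54 cells (Homo sapiens) for cytotoxicity, read by MTT assay, with a stated time of 72 h; a higher number here means a weaker inhibitor of growth, a lower number a stronger inhibitor of growth.
Compound 2 `CCCCCSc1nc(NCc2ccc([Se]C)cc2)c2ccccc2n1` gives 19800 nM in this assay.
Compound 3 `CSc1nc(NCc2ccc([Se]C)cc2)c2ccccc2n1` gives 57000 nM in this assay.

Among these three, compound 3 stands at the highest number in this assay; its nearest neighbour is compound 2, reached through a 2.9-fold higher number from compound 2 to compound 3 (0.46 log units; beyond the scatter), and compound 1 lies further away, with compound 1 at 7110 nM against compound 3 at 57000 nM. Compound 4 `CSc1ccc(CNc2nc(SC)nc3ccccc23)cc1` differs from compound 3 in one place: a group of 2 heavy atoms (1 carbon, 1 sulfur; no ring) in place of a group of 2 heavy atoms (1 carbon, 1 selenium; no ring), on an aromatic carbon.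

For the measured compounds named here, the only measured step, a 2.9-fold higher number from compound 2 to compound 3 (0.46 log units; beyond the scatter), concerns the chain on the sulfur of the shared core and not the exchange of selenium for sulfur on the outer ring, so no measured step bears directly on the change from compound 3 to compound 4. Compound 1 carries selenium at a different place and differs from compound 3 elsewhere as well, so it cannot be read as a single-point comparison. Going by the values given here, with no direct precedent, the expected step of a 1.1-fold higher number from compound 3 to compound 4 (0.02 log units; within the scatter) is taken as small, not beyond the scatter. Compound 4 is therefore estimated at 60000 nM in this assay, with a range from 20000 nM to 160000 nM.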

Compound 4, concentration for 50% growth inhibition: 7220 nM
Beside the measured number, compound 4's estimate is 8.3-fold (0.92 log units) above it; the whole stated range lies above it.
By their numbers in this assay, from the lowest: compounds 1 and 4 (each within the scatter of the next); then compound 2; then compound 3.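

In this assay the exchange of the selenium-bearing group for methylsulfanyl, on an aromatic carbon para to a large group, gives a 7.9-fold lower number from compound 3 to compound 4 (0.90 log units; beyond the scatter) and so makes the sulfur compound the stronger inhibitor of growth of this pair. The earlier compounds had shown only the effect of the chain on the sulfur of the shared core, in a 2.9-fold higher number from compound 2 to compound 3 (0.46 log units; beyond the scatter) as the one measured step, whereas this result shows that the single atom joining this group to the ring also matters for the number. No available evidence accounts for the change.

As far as these compounds go, whether the same exchange would give a step of similar size with the longer sulfur chain of compound 2 remains open. Also open, from the compounds shown here alone, is how other groups at this aromatic carbon, such as an amine, a chlorine atom or a longer alkylsulfanyl chain, would stand in this assay against methylsulfanyl.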